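The source may hold more compounds than are shown below. What is called first, only, known or untested is meant among the compounds shown, and "the series" means these compounds.

Compound 1 `CNC(=O)c1cc(Oc2cccc(NC(=S)Nc3ccc(F)c(F)c3)c2)ccn1` gives 30300 nM in a functional assay on HCT-116 cells (Homo sapiens) for cytotoxicity, read by MTT assay, with a stated time of 48 h; on this read-out lower numbers stand for stronger inhibition and higher numbers for weaker inhibition.
Compound 2 `CCNC(=O)c1cc(Oc2cccc(NC(=S)Nc3ccc(F)c(F)c3)c2)ccn1` gives 30300 nM in this assay.
Compound 3 `O=C(c1cc(Oc2cccc(NC(=S)Nc3ccc(F)c(F)c3)c2)ccn1)N1CCCC1` gives 52000 nM in this assay.

Compound 3 has the highest of the three numbers, but its gap to each of the others is small: a 1.7-fold higher number from compound 1 to compound 3 (0.23 log units; within the scatter) and a 1.7-fold higher number from compound 2 to compound 3 (0.23 log units; within the scatter). Likewise no change at the digits printed from compound 1 to compound 2 (within the scatter). All three compounds, which differ only in the group on the carbonyl carbon, therefore sit within the scatter of one another, and none can be called more or less potent than the rest.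

Compound 4 `O=C(c1cc(Oc2cccc(NC(=S)Nc3ccc(Cl)c(C(F)(F)F)c3)c2)ccn1)N1CCCC1` is the compound still to be measured. Relative to compound 3, the change is 4-chloro-3-(trifluoromethyl)phenyl in place of 3,4-difluorophenyl on an amide-type nitrogen, on the amide-type nitrogen whose other neighbour is the thiocarbonyl carbon. For the measured compounds named here, every measured step so far altered only the group on the carbonyl carbon; none of them bears on a change at this end of the molecule, so the measured data give no direction for it. The expectation for compound 4 is therefore a number close to that of compound 3, carried with a wide range, which means an expected step of a 1.7-fold lower number from compound 3 to compound 4 (0.24 log units; within the scatter). The estimate for compound 4 in this assay is 30000 nM, expected to fall between 7000 nM and 130000 nM.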

Compound 4, half-maximal inhibitory concentration: 22400 nM
The estimate for compound 4 lay 1.3-fold (0.13 log units) above the measured number; the measured number falls inside the stated range.
By their numbers in this assay, from the lowest: compounds 4, 1, 2 and 3 (each within the scatter of the next, the first and the last beyond it).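

Changing the aryl group on the amide-type nitrogen whose other neighbour is the thiocarbonyl carbon moves the number in this assay by more than any change at the carbonyl carbon did: 4-chloro-3-(trifluoromethyl)phenyl in place of 3,4-difluorophenyl gives a 2.3-fold lower number from compound 3 to compound 4 (0.37 log units; beyond the scatter). This is the only step shown that lies beyond the scatter, so this end of the molecule has some influence on the cytotoxicity read-out, although the effect is modest and rests on a single pair of compounds. No measured evidence here accounts for the difference.

On these data alone, the swap alters both the substituents and their places on the phenyl ring at once, so it remains open how much of the step belongs to the chlorine and how much to the trifluoromethyl group, which a phenyl ring carrying only one of them, or an unsubstituted phenyl ring, could help to separate. As far as these compounds go, it also remains open whether the same swap lowers the number when methylamino or ethylamino, rather than pyrrolidin-1-yl, sits on the carbonyl carbon.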